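The source may hold more compounds than are shown below. What is called first, only, known or untested is meant among the compounds shown, and "the series" means these compounds.

Compound 2 `CCCn1c(C)nc2cc3c(cc21)C1CNCC3C1` stands lowest of the three numbers measured in an assay on HEK293 cells for binding affinity to Neuronal acetylcholine receptor; alpha4/beta2 (Homo sapiens); on this read-out lower numbers stand for stronger inhibition and higher numbers for weaker inhibition. In this assay compound 2 gives 0.19 nM. Compound 1 `N#Cc1ccc2c(c1)C1CNCC2C1` gives 0.5 nM, and compound 3 `O=S(=O)(c1ccc2c(c1)C1CNCC2C1)N1CC1` gives 2 nM. Going by the values given here, the one step between compounds that differ in a single place runs a 4.0-fold higher number from compound 1 to compound 3 (0.60 log units; beyond the scatter), a change on an aromatic carbon of the shared core. Among the compounds with values here, compound 1 and compound 2 differ in more than one place, so their values show only that compound 2 sits lower.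

Compound 4 `Cc1nc2cc3c(cc2n1-c1ccccc1)C1CNCC3C1` differs from compound 2 in one place: phenyl in place of propyl on an aromatic nitrogen. Within the data shown here, no measured step touches this aromatic nitrogen, and no measured pair swaps a chain for an aromatic ring, so the measured steps give no direct guide. The step from compound 1 to compound 3 shows that enlarging a substituent on the shared core can weaken binding modestly, and a similar or smaller weakening is expected here. Compound 4 is therefore estimated to give 0.5 nM, within 0.1 nM to 3 nM, an expected step of a 2.6-fold higher number from compound 2 to compound 4 (0.42 log units; beyond the scatter).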

Compound 4, inhibition constant: < 5 nM
Compound 4: a limit, no number (the forecaster's own chance of this, stated with the estimate: 0%); the middle value is on the limit's open side.
By their numbers in this assay, from the lowest: compound 2; then compound 1; then compound 3.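

In this assay, going by these compounds alone, compound 4 gives < 5 nM, which is a limit and not a number, so no step from compound 2 to compound 4 can be read. The compounds shown leave open whether phenyl in place of propyl on the aromatic nitrogen raises or lowers the number, and by how much.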